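Taking the Drawn Configuration Away from Compound 1

The source may hold more compounds than are shown below. What is called first, only, known or untested is meant among the compounds shown, and "the series" means these compounds.

Measured so far:
compound 1 `Cc1nc(N)sc1CCCNC(=N)NC(=O)C[C@H](C)C1CCCCC1` gives 14.1 nM in an in vitro functional assay on Sf9 cells for agonist activity at histamine H2 receptor (Cavia porcellus), read by GTPgammaS binding; a lower number here means that less compound is needed, a higher number that more compound is needed for the effect
compound 2 `C[C@H](CC(=O)NC(=N)NCCCc1c[nH]cn1)c1ccccc1` gives 75.9 nM
compound 3 `C[C@@H](CC(=O)NC(=N)NCCCc1c[nH]cn1)c1ccccc1` gives 24 nM

Compound 1 has the lowest number of the three. Compound 3 is nearest to it, within the scatter, while compound 2 is furthest, beyond the scatter. Compound 4 `Cc1nc(N)sc1CCCNC(=N)NC(=O)CC(C)C1CCCCC1` is the next compound to be tested. It differs from compound 1 in one place only: the two compounds have the same atoms and bonds; at least one stereo element is drawn with a configuration in one of them and without one in the other: 1 of 2 stereo elements differ; a stereocentre at a saturated chain carbon is drawn S in compound 1 and without a configuration in compound 4. For the measured compounds named here, one measured step bears on this kind of change, a 3.2-fold lower number from compound 2 to compound 3 (0.50 log units; beyond the scatter), where the two compounds also share all atoms and bonds and differ only at one stereocentre; the evidence behind that step is the fact that one of compounds 2 and 3 is drawn with a defined configuration and the other without, at the place where they differ. Compound 4 keeps the drawn form of compound 1 but no longer fixes it, so it is expected to carry a somewhat higher number, a step of a 1.6-fold higher number from compound 1 to compound 4 (0.19 log units; within the scatter), close to the edge of the scatter. Compound 4 is therefore estimated at 22 nM, with a range from 11 nM to 45 nM.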

Compound 4, half-maximal effective concentration: 7.59 nM
Compound 4: the middle estimate sits 2.9-fold (0.46 log units) above what was measured; the whole stated range lies above it.
By their numbers in this assay, from the lowest: compounds 4, 1 and 3 (each within the scatter of the next, the first and the last beyond it); then compound 2.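

In this assay, taking away the drawn configuration at the saturated chain carbon gives a 1.9-fold lower number from compound 1 to compound 4 (0.27 log units; within the scatter), so for this core with its cyclohexyl group, the drawing of that centre makes no difference that can be told apart from the scatter. The earlier pair looked different, with a 3.2-fold lower number from compound 2 to compound 3 (0.50 log units; beyond the scatter) at the same kind of centre, but that pair carries a phenyl group and a different core. What is on record for the new step concerns the drawing alone: the fact that one of compounds 1 and 4 is drawn with a defined configuration and the other without, at the place where they differ

As far as these compounds go, how far the forms drawn S and R of compound 1 lie apart stays open, as does whether the phenyl group or the core goes with the larger step. Also open, from the compounds shown here alone, is how this centre behaves when its methyl is replaced by an ethyl group.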